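A few compounds are considered here, and "the series" means these few. Any claim that something is new, unique, unknown or untested is made for them only; others in the source may bear on it.

Measured so far in an in vitro functional assay on HEK285-7 cells for antagonist activity at prostaglandin D2 receptor 2 (Homo sapiens), read by BRET and beta-arrestin recruitment; on this read-out higher numbers stand for weaker inhibition and lower numbers for stronger inhibition:
- Compound 1 `O=C(O)Cc1sc(C(c2ccc(F)cc2)c2ccc(F)cc2)nc1-c1ccccc1`: 240 nM
- Compound 2 `O=C(O)Cc1sc(C(c2ccc(F)cc2)c2ccc(F)cc2)nc1-c1cc(F)cc(F)c1`: 340 nM
- Compound 3 `N#Cc1cc(-c2nc(C(c3ccc(F)cc3)c3ccc(F)cc3)sc2CC(=O)O)ccc1F`: 520 nM

Compound 3 gives the highest of the three numbers. Its gap to compound 2 is within the scatter, so the two cannot be ranked; its gap to compound 1 is beyond the scatter, a modest one, as a 2.2-fold higher number from compound 1 to compound 3 (0.34 log units; beyond the scatter) shows.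

Compound 4 `O=C(O)Cc1sc(C(c2ccc(F)cc2)c2ccc(F)cc2)nc1-c1ccco1` differs from compound 3 in one place: furan-2-yl in place of 3-cyano-4-fluorophenyl on an aromatic carbon. All three measured steps change the group on the same aromatic carbon of the shared core and therefore bear on it: a 1.4-fold higher number from compound 1 to compound 2 (0.15 log units; within the scatter), a 2.2-fold higher number from compound 1 to compound 3 (0.34 log units; beyond the scatter) and a 1.5-fold higher number from compound 2 to compound 3 (0.18 log units; within the scatter). Exchanges of the six-membered ring there have moved the number by at most a modest amount. Among the measured compounds shown here, no measured step exchanges that ring for a five-membered one, so the direction of this step cannot be read from the measured compounds. The expected step of a 1.7-fold lower number from compound 3 to compound 4 (0.24 log units; within the scatter) is therefore small, with no clear direction, and the range is set wide. Compound 4 is expected to give about 300 nM in this assay, within 120 nM to 800 nM.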

Compound 4, half-maximal inhibitory concentration: 140 nM
Compound 4: middle estimate off by 2.1-fold (0.33 log units), on the high side; low and high end bracket the measured number.
By their numbers in this assay, from the lowest: compounds 4, 1, 2 and 3 (each within the scatter of the next, the first and the last beyond it).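

On this aromatic carbon, furan-2-yl, the only five-membered ring among the compounds shown, gives a clear shift from the two substituted phenyl groups: a 3.7-fold lower number from compound 3 to compound 4 (0.57 log units; beyond the scatter) and a 2.4-fold lower number from compound 2 to compound 4 (0.39 log units; beyond the scatter). Against unsubstituted phenyl no order can be drawn (a 1.7-fold lower number from compound 1 to compound 4 (0.23 log units; within the scatter)), so the position accepts a ring with 5 heavy atoms and a hetero atom, and the shift holds only against 3,5-difluorophenyl and 3-cyano-4-fluorophenyl. No measurement at hand accounts for these differences.

The compounds shown do not separate ring size from the ring oxygen. On these data alone, a thiophen-2-yl group, with sulfur in place of that oxygen, or a saturated tetrahydrofuran-2-yl ring would bear on that question, and the effect of substituents on the furan ring also stays open.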